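A thiophene for a pyridine on a weak cytotoxic scaffold

The source may hold more compounds than are shown below. What is called first, only, known or untested is meant among the compounds shown, and "the series" means these compounds.

Compound 1 `Oc1ccc(-c2cc(-c3ccccn3)nc(-c3ccccc3Cl)c2)cc1` gives "not determined" (no result reported) in a functional assay on DU-145 cells (Homo sapiens) for cytotoxicity, read by CCK-8 assay and cell counting, with a stated time of 2 days (a lower number here means a stronger inhibitor, a higher number a weaker inhibitor), so it cannot be placed on any number. Its isomer compound 2 `Oc1ccc(-c2cc(-c3cccc(Cl)c3)nc(-c3ccccn3)c2)cc1` gives 35200 nM in this assay. Compound 3 `Oc1ccc(-c2cc(-c3ccsc3)nc(-c3ccccc3Cl)c2)cc1` differs from compound 1 by a single exchange, (thiophen-3-yl in place of pyridin-2-yl on an aromatic carbon). For the measured compounds named here, with no measured step to build on, this change is expected to shift the readout in this assay little, if at all, beyond the usual scatter, and in no clear direction. Taking compound 2 with its 35200 nM as the nearest guide, compound 3 is estimated to fall near 30000 nM, within a range from 8000 nM to 100000 nM.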

Compound 3, half-maximal inhibitory concentration: 3890 nM
Estimate against measurement, compound 3: 7.7-fold (0.89 log units) above; the whole stated range lies above it.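

For the compounds shown here, compound 1 has no single number in this assay, so no step to compound 3 can be read. What exchanging pyridin-2-yl for thiophen-3-yl does to the readout stays open, and nothing at hand accounts for the value of compound 3.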